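Acetylation of the hydroxymethyl of compound 1

A few compounds are considered here, and "the series" means these few. Any claim that something is new, unique, unknown or untested is made for them only; others in the source may bear on it.

Three compounds of the series carry numbers in an assay (Oryctolagus cuniculus) for inhibition of platelet-activating factor receptor (Cavia porcellus); a higher number here means a weaker inhibitor, a lower number a stronger inhibitor. Compound 1 `C/C1=C\CC[C@@]2(C)O[C@@H]2C(=O)[C@@H]2CC[C@@H](C)[C@](C)(CC1)[C@H]2CO` gives 1300 nM in this assay. Compound 2 `C[C@@H]1CC[C@H]2C(=O)[C@H]3O[C@]3(C)CC[C@@H]3O[C@@]3(C)CC[C@]1(C)[C@H]2C=O` gives 17000 nM, and compound 3 `C[C@@H]1CC[C@H]2C(=O)[C@H]3O[C@]3(C)CC[C@@H]3O[C@@]3(C)CC[C@]1(C)[C@H]2CO` gives 30000 nM. Compound 1 therefore stands lowest of the three, and both other compounds lie beyond the scatter from it. Going by the values given here, the only step between measured compounds that differ in one place is a 1.8-fold higher number from compound 2 to compound 3 (0.25 log units; within the scatter), hydroxymethyl in place of formyl on a saturated ring carbon.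

Compound 4 `CC(=O)OC[C@H]1[C@H]2CC[C@@H](C)[C@]1(C)CC/C(C)=C/CC[C@@]1(C)O[C@@H]1C2=O` has not been measured. It differs from compound 1 by acetyl in place of hydrogen on an oxygen on a saturated carbon. Among the compounds with values here, no measured pair shows an acetyl entering anywhere, so there is no direct precedent. Within the data shown here, the one measured step at the same saturated carbon, the exchange of formyl for hydroxymethyl, stayed within the scatter, which gives no reason to expect a large movement from a further change at that carbon. The expectation is thus a step of no clear direction and of a size not beyond the scatter.

Compound 4 is expected to give 1600 nM in this assay, a step of a 1.2-fold higher number from compound 1 to compound 4 (0.09 log units; within the scatter). The estimated range for compound 4 runs from 500 nM to 5000 nM.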

Compound 4, half-maximal inhibitory concentration: 410 nM
Beside the measured number, compound 4's estimate is 3.9-fold (0.59 log units) above it; measured number below the stated range.
By their numbers in this assay, from the lowest: compound 4; then compound 1; then compounds 2 and 3 (each within the scatter of the next).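

In this assay, the oxygen on the saturated carbon of compound 1 accepts a substituent: acetyl in place of hydrogen gives a 3.2-fold lower number from compound 1 to compound 4 (0.50 log units; beyond the scatter), a modest step. Going by these compounds alone, the hydroxy hydrogen is therefore not needed for a number in this range, and hydroxymethyl to acetoxymethyl is the first change at this place seen to lie beyond the scatter, whereas a 1.8-fold higher number from compound 2 to compound 3 (0.25 log units; within the scatter), on a different core, does not. The data give no explanation for the lower number that comes with the acetyl.

The compounds shown leave open whether this step belongs to acetyl itself or would also appear with a longer acyl chain such as butanoyl, with benzoyl, or with a simple methyl ether on the same oxygen. They also leave open whether acetyl on the oxygen of compound 3 , which starts from a much higher number, would give a step of similar size and direction, or whether the step seen here holds only for the core of compound 1 .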